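A Methyl Added to the Amide Analogue

The source may report more compounds than this note shows. Statements on the series, on what has been measured and on what is new or still open speak of the compounds shown alone.

Measured so far:
compound 1 `CN(/N=C/c1cnn2ccc(C#N)cc12)S(=O)(=O)c1cc([N+](=O)[O-])ccc1F` gives 480 nM in a functional assay on NZB5 cells (Homo sapiens) for inhibition, read by thymidine incorporation, with a stated time of 5 days; a higher number here means a weaker inhibitor, a lower number a stronger inhibitor
compound 2 `Cc1ccc(Br)cc1S(=O)(=O)N(C)/N=C/c1cnn2ccc(C#N)cc12` gives 700 nM in this assay
compound 3 `CN(/N=C/c1cnn2ccc(C#N)cc12)C(=O)c1cccc([N+](=O)[O-])c1` gives 1800 nM in this assay

All three compounds share the same core and differ in the group attached to the methylated nitrogen of the hydrazone. Compound 3 stands at the highest of the three numbers in this assay, so it is the weakest inhibitor of the set. Its nearest neighbour is compound 2, whose number is lower by a margin beyond the usual scatter, and compound 1 lies furthest away with a lower number still. Among the measured compounds shown here, compound 3 carries a carbonyl where compounds 1 and 2 carry a sulfonyl, and its aromatic ring bears a different set of substituents, so no pair of measured compounds differs in just one place.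

Compound 4 `Cc1ccc([N+](=O)[O-])cc1C(=O)N(C)/N=C/c1cnn2ccc(C#N)cc12` differs from compound 3 by methyl in place of hydrogen on an aromatic carbon. For the measured compounds named here, no measured pair isolates this change. Compound 2 has a methyl in a similar setting on a sulfonamide, but alongside a different ring substituent, so its value does not show what the methyl alone does. A small step is expected in this assay, within the scatter and in no firm direction. Compound 4 is therefore estimated at 1500 nM, with a range from 600 nM to 4000 nM, which corresponds to an expected step of a 1.2-fold lower number from compound 3 to compound 4 (0.08 log units; within the scatter).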

Compound 4, half-maximal inhibitory concentration: > 20000 nM
Compound 4 ended at the assay's limit; the forecaster's own chance of this, stated with the estimate: 3%; at least 13-fold (1.12 log units) between middle value and limit.
By their numbers in this assay, from the lowest: compounds 1 and 2 (each within the scatter of the next); then compound 3. At a limit, above all of these: compound 4.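

In this assay, among the compounds shown here, the single change of methyl in place of hydrogen, on an aromatic carbon ortho to a large group and para to a nitro group, gives an at least 11-fold higher number from compound 3 to compound 4 (1.04 log units; beyond the scatter). This is the first step among the compounds shown that isolates one change, and it shows that one added carbon atom at this position can turn a compound with a measurable number into one that reaches the end of the assay's range. Compound 4 stands at a limit of the assay and not at a measured number, so the step gives only the smallest size the change can have: the limit of > 20000 nM in this assay, at which 1 of the 4 values shown sits.

The compounds shown leave open whether this sharp loss of inhibition belongs to methyl in particular or would follow any group on this carbon, a question that a fluorine atom, a hydroxyl group or a methoxy group there could help to answer. They also leave open whether the same exchange of hydrogen for methyl would have a similar effect in a compound with a sulfonyl in place of the carbonyl.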